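From morpholin-4-yl to 4-aminopiperidin-1-yl on a sulfonyl sulfur

The source may hold more compounds than are shown below. What is called first, only, known or untested is meant among the compounds shown, and "the series" means these compounds.

In an ADME assay on Vero cells (Chlorocebus sabaeus) for cytotoxicity, read by MTT assay (on this read-out lower numbers stand for higher toxicity in this test and higher numbers for lower toxicity in this test), compound 3 (`Cn1nc(C(F)(F)F)cc1C(=O)Nc1ccc(S(=O)(=O)N2CCOCC2)cc1`) reads > 300000 nM and this is a limit, not a number. It therefore sits at the limit of > 300000 nM in this assay, at which 1 of the 3 values shown sits, in this small set. Compound 1 (`Cn1nc(C(F)(F)F)cc1C(=O)Nc1ccc(S(=O)(=O)N2CCC(C(F)(F)F)CC2)cc1`) gives 159000 nM and compound 2 (`Cn1nc(C(F)(F)F)cc1C(=O)Nc1ccc(S(=O)(=O)NC2CCCCC2)cc1`) gives 15000 nM in this assay under the same conditions. Compound 4 (`Cn1nc(C(F)(F)F)cc1C(=O)Nc1ccc(S(=O)(=O)N2CCC(N)CC2)cc1`) carries 4-aminopiperidin-1-yl in place of morpholin-4-yl on a sulfonyl sulfur. Among the measured compounds shown here, two measured steps bear on this change: an at least 1.8-fold higher number from compound 1 to compound 3 (0.27 log units; that floor lies within the scatter) whose floor lies within the scatter, and an at least 20-fold higher number from compound 2 to compound 3 (1.30 log units; beyond the scatter) which is large. Only compound 2 thus points clearly to a lower number without morpholin-4-yl. The estimate is an at least 3.3-fold lower number from compound 3 to compound 4 (0.52 log units; beyond the scatter) as an expected moderate fall in this assay for this change. The expected value for compound 4 is 90000 nM within a range of 25000 nM to 300000 nM as estimated here.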

Compound 4, half-maximal cytotoxic concentration: > 300000 nM
Compound 4 was reported as a limit; the forecaster's own chance of this, stated with the estimate: 20%; at least 3.3-fold (0.52 log units) between middle value and limit.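

In this assay, compound 4 reads > 300000 nM, which is a limit, so morpholin-4-yl is not the only group on the sulfonyl sulfur to reach it: the limit of > 300000 nM in this assay, at which 2 of the 4 values shown sit.

With 4-aminopiperidin-1-yl in place of cyclohexylamino there is an at least 20-fold higher number from compound 2 to compound 4 (1.30 log units; beyond the scatter), and with amino in place of trifluoromethyl on a saturated ring carbon there is an at least 1.8-fold higher number from compound 1 to compound 4 (0.27 log units; that floor lies within the scatter), so only the first is a clear rise. Both values are limits, and the step from compound 3 to compound 4 cannot be read.

The compounds shown leave open how far compound 3 and compound 4 lie apart. They also leave open whether a carboxylic acid or a longer chain ending in an amine, carried on the sulfonyl sulfur, would stay at this limit.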